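Replacing a benzyl amide with a dimethylphenyl amide

The source may hold more compounds than are shown below. What is called first, only, known or untested is meant among the compounds shown, and "the series" means these compounds.

Compound 1, `COc1ccc2c(=O)c(/C=C/C(=O)Nc3cccc(Cl)c3)coc2c1`, in a functional assay (QGY7701 cells, Homo sapiens) for inhibition, read by MTT assay, with a stated time of 48 h (a higher number here means a weaker inhibitor, a lower number a stronger inhibitor), reports only a limit: > 100000 nM.
Compound 2, `COc1ccc2c(=O)c(/C=C/C(=O)Nc3ccc(C)cc3)coc2c1`, gives 39300 nM.
Compound 3, `COc1ccc2c(=O)c(/C=C/C(=O)NCc3cccc(F)c3)coc2c1`, gives 28600 nM.

All three share one core and differ only in the group on the amide-type nitrogen. Compound 3 carries the lowest number shown, yet its gap to compound 2, a 1.4-fold lower number from compound 2 to compound 3 (0.14 log units; within the scatter), lies within the scatter, so the two cannot be ranked. The steps from compound 1 are larger, an at least 2.5-fold lower number from compound 1 to compound 2 (0.40 log units; beyond the scatter) and an at least 3.4-fold lower number from compound 1 to compound 3 (0.54 log units; beyond the scatter), though both rest on the limit of > 100000 nM in this assay, at which 1 of the 3 values shown sits, and their true size is not known.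

Compound 4, `COc1ccc2c(=O)c(/C=C/C(=O)Nc3cc(C)ccc3C)coc2c1`, is not yet measured. 2,5-dimethylphenyl in place of 3-fluorobenzyl on an amide-type nitrogen The change puts a phenyl ring bearing two methyl groups on the amide-type nitrogen, as compound 2 carries a methyl-bearing phenyl, while the fluorine of compound 3 is lost. The step between a phenyl and a benzyl group, a 1.4-fold lower number from compound 2 to compound 3 (0.14 log units; within the scatter), stayed within the scatter, and compound 2 sits close to compound 3. Going by the values given here, no measured compound carries a 2,5-dimethylphenyl, so the expectation rests on that nearness. Compound 4 is therefore expected to show a step of a 1.4-fold higher number from compound 3 to compound 4 (0.15 log units; within the scatter), not beyond the scatter in either direction. The estimate for compound 4 is 40000 nM, between 15000 nM and 110000 nM.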

Compound 4, half-maximal inhibitory concentration: > 100000 nM
Compound 4 gave a limit, no number (the forecaster's own chance of this, stated with the estimate: 25%); at least 2.5-fold (0.39 log units) between middle value and limit.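

In this assay, the group on the amide-type nitrogen matters beyond the choice of phenyl or benzyl: there is an at least 2.5-fold higher number from compound 2 to compound 4 (0.40 log units; beyond the scatter), although both compounds carry a methyl-bearing phenyl ring. The swap of 3-fluorobenzyl for 2,5-dimethylphenyl also gives a clear change, with an at least 3.4-fold higher number from compound 3 to compound 4 (0.54 log units; beyond the scatter), even though the leaving and entering groups have the same number of heavy atoms and one aromatic ring each. These two steps give only minimum sizes, and the step linking compound 1 and compound 4 cannot be read at all, because both of those compounds stop at a limit of the assay: the limit of > 100000 nM in this assay, at which 2 of the 4 values shown sit.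

The compounds shown cannot tell whether the loss seen with compound 4 comes from the number of methyl groups or from where they sit, since compound 2 is the only phenyl compound here with a measured number. Also open, on these data alone, is how this assay would read a phenyl ring carrying an amine or a carboxylic acid, or a longer chain in place of the benzyl group of compound 3.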